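Exchanging one carbamoyl chain for another

A few compounds are considered here, and "the series" means these few. Any claim that something is new, unique, unknown or untested is made for them only; others in the source may bear on it.

In an ADME assay on HOS cells (Homo sapiens) for cytotoxicity, read by luminescence and ATP content, with a stated time of 48 h (a higher number here means that more compound is tolerated, a lower number that less compound is tolerated), compound 1 (`Nc1c(C(=O)NCc2ccc(F)cc2F)c(=O)n(O)c2ncc(CCc3ccccc3)cc12`) gives 18000 nM. Compound 2 (`CN(C)C(=O)CCc1cnc2c(c1)c(N)c(C(=O)NCc1ccc(F)cc1F)c(=O)n2O`) gives > 250000 nM, which is a limit of the assay and not a number. Among the measured compounds shown here, the only measured step, an at least 13-fold higher number from compound 1 to compound 2 (1.14 log units; beyond the scatter), lies beyond the scatter and came with dimethylcarbamoyl in place of phenyl on a saturated chain carbon.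

Compound 3 (`CC(C)NC(=O)/C=C/c1cnc2c(c1)c(N)c(C(=O)NCc1ccc(F)cc1F)c(=O)n2O`) differs from compound 2 in one place: 2-(isopropylcarbamoyl)ethenyl in place of 2-(dimethylcarbamoyl)ethyl on an aromatic carbon. In words, 2-(isopropylcarbamoyl)ethenyl stands in place of 2-(dimethylcarbamoyl)ethyl on an aromatic carbon. The measured step bears on this only indirectly, as it replaced phenyl, whereas here one carbamoyl-bearing group gives way to another. Compound 3 is therefore expected to keep much of the large gain seen in an at least 13-fold higher number from compound 1 to compound 2 (1.14 log units; beyond the scatter), without any measured step to show that it keeps all of it. A modest fall is expected, and the size expected is an at least 2.0-fold lower number from compound 2 to compound 3 (0.31 log units; beyond the scatter). The estimated value in this assay for compound 3 is 120000 nM, with an expected range from 35000 nM to 250000 nM.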

Compound 3, half-maximal cytotoxic concentration: > 250000 nM
Compound 3: a limit, no number (the forecaster's own chance of this, stated with the estimate: 40%); middle value at least 2.0-fold (0.31 log units) from the limit.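

In this assay, 2-(isopropylcarbamoyl)ethenyl in place of phenethyl on an aromatic carbon brings an at least 13-fold higher number from compound 1 to compound 3 (1.14 log units; beyond the scatter), so the large step away from compound 1 is no longer tied to one chain. At this position, a second carbamoyl chain, with an ethenyl link and the amide hydrogen, goes with the same reading as the 2-(dimethylcarbamoyl)ethyl chain of compound 2, and neither returns to the value of compound 1. Whether the exchange between these two carbamoyl chains moves the number at all cannot be read, because compound 2 and compound 3 both rest on a limit of the assay and not on a number: the limit of > 250000 nM in this assay, at which 2 of the 3 values shown sit.

From the compounds shown here alone, it remains open whether the large step depends on the carbamoyl group or on the loss of the terminal phenyl, and a chain ending in an amine or a carboxylic acid at this position would bear on that question. Going by these compounds, it also remains open how far the true values of compound 2 and compound 3 lie beyond the limit, and whether they differ from each other.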